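This account rests on a few compounds, and the source may have more. Where it says the series, first, only, none or still open, it means among the compounds named here.

Measured compounds in a functional assay on cells for antagonist activity at prostaglandin E2 receptor EP1 subtype (Rattus norvegicus), read by fluorescence and calcium flux, with a stated time of 60 s; a higher number here means a weaker inhibitor, a lower number a stronger inhibitor:
compound 1, `O=C(O)c1cccc(Cc2c(-c3ccccc3)nn3ccccc23)n1`: 2300 nM
compound 2, `O=C(O)c1cccc(Cc2c(-c3ccccc3)nn3cc(F)ccc23)n1`: 380 nM
compound 3, `O=C(O)c1cccc(Cc2c(-c3ccccc3)nn3cc(C4CC4)ccc23)n1`: 190 nM

Compound 3 gives the lowest number of the three in this assay; compound 2 is its nearest neighbour, and the gap between compound 2 and compound 3 is within the scatter, so no order between them can be claimed. Compound 1 stands furthest away, and the step from it is beyond the scatter.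

Compound 4, `CSc1ccc2c(Cc3cccc(C(=O)O)n3)c(-c3ccccc3)nn2c1`, differs from compound 3 in one place: methylsulfanyl in place of cyclopropyl on an aromatic carbon. The measured steps that bear on this are a 12-fold lower number from compound 1 to compound 3 (1.08 log units; beyond the scatter), a 6.1-fold lower number from compound 1 to compound 2 (0.78 log units; beyond the scatter) and a 2.0-fold lower number from compound 2 to compound 3 (0.30 log units; within the scatter). Both substituted compounds, compound 2 and compound 3, give much lower numbers than the unsubstituted compound 1, while the exchange of one substituent for another at this position, from compound 2 to compound 3, stays within the scatter. Methylsulfanyl is a third substituent at the same position, so the account expects compound 4 to stay close to compound 3, with a step of about a 1.4-fold higher number from compound 3 to compound 4 (0.14 log units; within the scatter), not beyond the scatter. The estimate for compound 4 in this assay is 260 nM, with a range from 100 nM to 700 nM.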

Compound 4, half-maximal inhibitory concentration: 87 nM
Estimate against measurement, compound 4: 3.0-fold (0.48 log units) above; the whole stated range lies above it.
By their numbers in this assay, from the lowest: compound 4; then compounds 3 and 2 (each within the scatter of the next); then compound 1.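

The earlier exchange of one substituent for another at this position stayed within the scatter (a 2.0-fold lower number from compound 2 to compound 3 (0.30 log units; within the scatter)), but in this assay the exchanges that bring in methylsulfanyl do not (a 2.2-fold lower number from compound 3 to compound 4 (0.34 log units; beyond the scatter); a 4.4-fold lower number from compound 2 to compound 4 (0.64 log units; beyond the scatter)), so the choice of substituent here matters and not only its presence. Compound 4 also has the largest step from the unsubstituted compound (a 26-fold lower number from compound 1 to compound 4 (1.42 log units; beyond the scatter)), and its steps to all three other compounds lie beyond the scatter, which shows that among these compounds a ring on this aromatic carbon is not needed for the lowest number, since methylsulfanyl has no ring and fewer heavy atoms than cyclopropyl. No measurement here accounts for the difference between methylsulfanyl and cyclopropyl at this position.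

The compounds shown leave open whether the sulfur itself counts, which a methoxy group, or a longer chain such as ethylsulfanyl, at the same carbon would help to separate. They also leave open how far this result carries to an amine or a methylsulfonyl group at this position, and whether it holds when the phenyl group or the carboxylic acid of the shared core is changed.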